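This account rests on a few compounds, and the source may have more. Where it says the series, first, only, none or still open, it means among the compounds named here.

Measured so far in a physicochemical assay for lipophilicity, at pH 7.4; a lower number here means a more polar compound, a higher number a more lipophilic compound:
compound 1 `Cc1cc(C(=O)NC(C)C)nn1Cc1cc(Cl)ccc1OCc1ccccc1`: > 3.7
compound 2 `Cc1cc(C(=O)Nc2ccccc2)nn1Cc1cc(Cl)ccc1OCc1ccccc1`: > 3.7
compound 3 `Cc1cc(NC(=O)OC(C)(C)C)nn1Cc1cc(Cl)ccc1OCc1ccccc1`: > 3.7

In this assay compound 2 gives > 3.7, and this is a limit of the assay rather than a number. The same holds for every value in the set so far (the limit of > 3.7 in this assay, at which 3 of the 3 values shown sit). The steps a step that the two limits leave unreadable from compound 1 to compound 2, a step that the two limits leave unreadable from compound 1 to compound 3 and a step that the two limits leave unreadable from compound 2 to compound 3 are accordingly all unreadable; none gives a measured size for a change at this position of the shared core. Compound 4 `COC(=O)Nc1cc(C)n(Cc2cc(Cl)ccc2OCc2ccccc2)n1` differs from compound 2 as follows: (methoxycarbonyl)amino in place of phenylcarbamoyl on an aromatic carbon. Going by the values given here, no measured step bears on the size of this change. The step from compound 2 to compound 4 in this assay is nonetheless expected to point downward, a number at least 0.10 log units lower from compound 2 to compound 4 (that floor lies within the scatter), with its size uncertain. Compound 4 is expected at 3.6, within 3 to 4.2, and it may again fall at the limit.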

Compound 4, distribution coefficient: > 3.7
Compound 4: no number, only a limit; the forecaster's own chance of this, stated with the estimate: 45%; at least 0.10 log units between middle value and limit.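

In this assay, going by these compounds alone, compound 4 gives > 3.7 as a limit and not a number, so no step linking it to compound 1, compound 2 or compound 3 can be read. The compounds shown leave open the size of every change at this position of the shared core: the limit of > 3.7 in this assay, at which 4 of the 4 values shown sit.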